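Furan-2-yl to thiophen-2-yl step from compound 3

A few compounds are considered here, and "the series" means these few. Any claim that something is new, unique, unknown or untested is made for them only; others in the source may bear on it.

Three compounds of this series have numbers in a functional assay on U-87MG ATCC cells for antiproliferative activity against U-87 MG (Homo sapiens), read by MTT assay, with a stated time of 48 h; a lower number here means a stronger inhibitor, a higher number a weaker inhibitor. Compound 1 `O=C(/C=C/c1ccc(Oc2cc(=O)oc3ccccc23)cc1)/C=C/c1ccccn1` gives 50800 nM. Compound 2 `COc1cc(OC)c2c(=O)c(OCCCCOc3ccc(/C=C/C(=O)/C=C/c4ccccn4)cc3)c(-c3cc(OC)c(OC)c(OC)c3)oc2c1` gives 4690 nM. Compound 3 `COc1cc(OC)c2c(=O)c(OCCCCOc3ccccc3/C=C/C(=O)/C=C/c3ccco3)c(-c3cc(OC)c(OC)c(OC)c3)oc2c1` gives 10700 nM. Among the three, compound 3 holds the second highest number: compound 2 sits nearest with a lower number, a gap beyond the usual scatter, while compound 1 is furthest with a higher number, a gap also beyond the scatter. Within the data shown here, no pair among the measured compounds differs in one place only, so no single-point step is known from the measured set.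

Compound 4 `COc1cc(OC)c2c(=O)c(OCCCCOc3ccccc3/C=C/C(=O)/C=C/c3cccs3)c(-c3cc(OC)c(OC)c(OC)c3)oc2c1` is not yet measured. It differs from compound 3 in one place: thiophen-2-yl in place of furan-2-yl on a double-bonded chain carbon bound to a double-bonded chain carbon. Among the measured compounds shown here, there is no measured step on which to anchor this exchange; the expectation rests only on how alike the two groups are as counted in that difference. The expected step from compound 3 to compound 4 is small, a 1.3-fold lower number from compound 3 to compound 4 (0.13 log units; within the scatter), most likely within the scatter, leaning if anything toward a lower number. For compound 4 the estimate in this assay is 8000 nM, with a range from 3000 nM to 25000 nM.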

Compound 4, half-maximal inhibitory concentration: 21100 nM
Compound 4: the middle estimate sits 2.6-fold (0.42 log units) below what was measured; the range from low to high includes it.
By their numbers in this assay, from the lowest: compound 2; then compounds 3 and 4 (each within the scatter of the next); then compound 1.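

In this assay, among these compounds, thiophen-2-yl in place of furan-2-yl on a double-bonded chain carbon bound to a double-bonded chain carbon gives a 2.0-fold higher number from compound 3 to compound 4 (0.29 log units; within the scatter), the first step that can be read at a single place. Among the compounds shown here, compound 1, compound 2 and compound 3 formed no such pair, so this position had no reading until now; this one shows that an exchange of oxygen for sulfur in a five-membered aromatic ring, with the heavy-atom, donor and acceptor counts unchanged, is not resolved by this read-out. No measured property of either group bears on this result, so the step stands without an explanation.

Still open, on these data alone, is how a group of a different kind at this place would read, such as phenyl, or furan-2-yl carrying an aminomethyl group or a carboxylic acid. As far as these compounds go, it is also open whether the furan-2-yl to thiophen-2-yl exchange would read the same way on a compound with a longer chain joining the two halves of the molecule.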